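The compounds below may be only part of what the source reports. "The series", "measured", "known", "first", "only" and "open" are said of these compounds alone.

The measured compounds are compound 1, `CCCCNc1nc(N)nc2c1CN(Cc1ccccc1)CC2`, with 0.06 uM; compound 2, `CCCCNc1nc(N)nc2c1CN(C(C)=O)CC2`, with 0.5 uM; and compound 3, `CCCCNc1nc(N)nc2c1CN(Cc1cccc(OC)c1Cl)CC2`, with 0.04 uM, all in an assay on HEK293 cells for agonist activity at Toll-like receptor 8 (Homo sapiens), read by a luciferase reporter, with a stated time of 6 h; a lower number here means that less compound is needed, a higher number that more compound is needed for the effect.

Compound 1 stands second highest of the three numbers. Its nearest neighbour is compound 3, whose value lies within the scatter of compound 1, so no order between these two can be read. Among the compounds with values here, the furthest is compound 2, reached by the one step between measured compounds that differ in one place: an 8.3-fold higher number from compound 1 to compound 2 (0.92 log units; beyond the scatter), a modest rise beyond the scatter when acetyl replaces benzyl on the amine nitrogen in the ring.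

The unmeasured compound 4 is `CCCCNc1nc(N)nc2c1CN(Cc1c(Cl)cccc1Cl)CC2`. It differs from compound 1 by 2,6-dichlorophenyl in place of phenyl on a saturated chain carbon bound to an amine nitrogen in a ring. Within the data shown here, no measured step concerns substitution of that benzyl ring itself; the step from compound 1 to compound 2 bears on it only by showing that removing the benzyl altogether costs potency. The values of compound 1 and compound 3 show that a substituted benzyl ring gives a number indistinguishable from the plain one.

For compound 4 the expectation is therefore no step beyond the scatter, a 1.2-fold lower number from compound 1 to compound 4 (0.08 log units; within the scatter), and an estimated 0.05 uM, within 0.02 uM to 0.15 uM.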

Compound 4, minimum effective concentration: 0.14 uM
Compound 4: middle estimate off by 2.8-fold (0.45 log units), on the low side, and the stated range covers the measured number.
By their numbers in this assay, from the lowest: compounds 3 and 1 (each within the scatter of the next); then compound 4; then compound 2.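

In this assay, 2,6-dichlorophenyl in place of phenyl gives a 2.3-fold higher number from compound 1 to compound 4 (0.37 log units; beyond the scatter), so changes to the aromatic ring at this position can move the number beyond the scatter, whereas the substituted ring of compound 3 stayed within the scatter of compound 1. The position therefore tolerates some ring substitution but not all of it alike, although compound 4 with 0.14 uM still needs less compound than compound 2 with 0.5 uM and so keeps a lower number than the acetyl compound. Nothing measured here accounts for the difference between the two substituted rings.

The compounds shown leave open whether the higher number of compound 4 follows from the presence of chlorine as such or from its particular pattern, which a chlorophenyl group on the same saturated chain carbon would help to separate. They also leave open how a pyridine ring in place of phenyl, or a longer chain between the amine nitrogen in the ring and the phenyl, would fare in this assay.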